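The source may report more compounds than this note shows. Statements on the series, on what has been measured and on what is new or still open speak of the compounds shown alone.

Working notes on the series. Among the measured compounds shown here, in an ADME assay on HCT-116 cells (Homo sapiens) for cytotoxicity (a higher number here means a weaker inhibitor, a lower number a stronger inhibitor), compound 1 (`COc1ccc(-n2cnnc2-c2cc(OC)c(OC)c(OC)c2)cc1`) gives 230 nM, the higher of the two numbers so far. Compound 2 (`COc1cc(-c2nncn2-c2ccc(N(C)C)cc2)cc(OC)c1OC`) gives 91.5 nM. The next structure, compound 3 (`COc1ccc(-n2cnnc2-c2cc(OC)c(OC)c(OC)c2)cc1O`), differs from compound 1 by hydroxy in place of hydrogen on an aromatic carbon, ortho to a methoxy group and meta to a large group. For the measured compounds named here, only one measured step bears on this, and only indirectly: a 2.5-fold lower number from compound 1 to compound 2 (0.40 log units; beyond the scatter), with dimethylamino in place of methoxy on an aromatic carbon. Going by the values given here, that is a different change, and no measured compound carries a hydroxy group, so the direction remains uncertain. A modest move toward a lower number is tentatively expected, with the estimated step being a 2.1-fold lower number from compound 1 to compound 3 (0.32 log units; beyond the scatter). For compound 3 the estimate is 110 nM, with an expected range of 30 nM to 400 nM.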

Compound 3, half-maximal inhibitory concentration: 88.9 nM
The estimate for compound 3 lay 1.2-fold (0.09 log units) above the measured number; low and high end bracket the measured number.
By their numbers in this assay, from the lowest: compounds 3 and 2 (each within the scatter of the next); then compound 1.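

In this assay, hydroxy in place of hydrogen on an aromatic carbon, ortho to a methoxy group and meta to a large group, gives a 2.6-fold lower number from compound 1 to compound 3 (0.41 log units; beyond the scatter), so a substituent at this position moves the number beyond the scatter. The earlier step replaced the methoxy group itself, whereas this one keeps that methoxy group and changes a hydrogen on the same ring, showing that the ring can respond to a change at a second position. No measured property of these compounds bears on the step, and its cause stays unexplained.

From the compounds shown here alone, whether an amine, a fluorine or a second methoxy group on this same carbon would shift the number in the same direction remains open. Also open, going by these compounds, is whether hydroxy would give a similar step at another carbon of this ring.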